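Amino to nitro on a three-compound series

This account rests on a few compounds, and the source may have more. Where it says the series, first, only, none or still open, it means among the compounds named here.

Measured so far in a functional assay on A549 cells (Homo sapiens) for inhibition, read by CCK-8 assay, with a stated time of 48 h; on this read-out lower numbers stand for stronger inhibition and higher numbers for weaker inhibition:
compound 1 `COc1ccc(-c2cc3nccc(-c4cc(OC)c(OC)c(OC)c4)n3n2)cc1`: 376 nM
compound 2 `COc1ccc(-c2cc3nccc(-c4cc(OC)c(OC)c(OC)c4)n3n2)cc1F`: 545 nM
compound 3 `COc1ccc(-c2cc3nccc(-c4cc(OC)c(OC)c(OC)c4)n3n2)cc1N`: 138 nM

Compound 3 has the lowest number of the three, and its gaps to both others lie beyond the scatter. The next analogue, compound 4 `COc1ccc(-c2cc3nccc(-c4cc(OC)c(OC)c(OC)c4)n3n2)cc1[N+](=O)[O-]`, carries nitro in place of amino on an aromatic carbon, ortho to a methoxy group and meta to a large group: nitro in place of amino on an aromatic carbon.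

Within the data shown here, no nitro compound has been measured, so only the three steps at this same carbon bear on the change. Fluoro in place of hydrogen gave a 1.4-fold higher number from compound 1 to compound 2 (0.16 log units; within the scatter). Amino in place of hydrogen gave a 2.7-fold lower number from compound 1 to compound 3 (0.44 log units; beyond the scatter), and amino in place of fluoro gave a 3.9-fold lower number from compound 2 to compound 3 (0.60 log units; beyond the scatter). Only the amino compound stands apart, so with amino leaving, a modest step toward a higher number is expected in this assay, of about the size of a 3.9-fold lower number from compound 2 to compound 3 (0.60 log units; beyond the scatter). The estimated change is a 3.6-fold higher number from compound 3 to compound 4 (0.56 log units; beyond the scatter). Compound 4 is estimated at 500 nM, with an expected range from 170 nM to 1500 nM.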

Compound 4, half-maximal inhibitory concentration: > 10000 nM
Compound 4: a limit, no number (the forecaster's own chance of this, stated with the estimate: 5%); middle value at least 20-fold (1.30 log units) from the limit.
By their numbers in this assay, from the lowest: compound 3; then compounds 1 and 2 (each within the scatter of the next). At a limit, above all of these: compound 4.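

In this assay, compound 4 gives a limit of the assay and not a number: the limit of > 10000 nM in this assay, at which 1 of the 4 values shown sits. Nitro gives an at least 26-fold higher number from compound 1 to compound 4 (1.42 log units; beyond the scatter) against hydrogen, an at least 18-fold higher number from compound 2 to compound 4 (1.26 log units; beyond the scatter) against fluoro and an at least 72-fold higher number from compound 3 to compound 4 (1.86 log units; beyond the scatter) against amino, so all three steps are large even when read from the limit. The earlier steps at this carbon were modest or within the scatter, so this position had not yet shown how sharply the read-out can turn on the group placed there, and nitro alone among the four groups reaches the limit.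

From the compounds shown here alone, how far beyond the limit compound 4 truly lies stays unknown, and one nitro compound cannot say which feature of the group drives the loss. Going by these compounds, whether an acetamide, a hydroxyl or a nitrile on this carbon would follow amino or nitro also stays open.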